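A few compounds are considered here, and "the series" means these few. Any claim that something is new, unique, unknown or untested is made for them only; others in the source may bear on it.

Working notes on the series. Among the compounds with values here, compound 1 `CCOC(=O)C1=C(C)NC(=S)NC1c1ccc(SC)cc1` gives 23.6 ug/mL in a functional assay on PC-3 cells (Homo sapiens) for inhibition, read by sulforhodamine B assay, with a stated time of 48 h (a higher number here means a weaker inhibitor of growth, a lower number a stronger inhibitor of growth), the highest number of the two measured so far; compound 2 `CCOC(=O)C1=C(C)NC(=S)NC1C1CCCCC1` gives 0.46 ug/mL in this assay, a far lower number. Compound 3 `CCCc1ccc(C2NC(=S)NC(C)=C2C(=O)OCC)cc1` is not yet measured. It differs from compound 1 by propyl in place of methylsulfanyl on an aromatic carbon. Within the data shown here, no step between measured compounds isolates this change, so the expectation rests on compound 1 alone: the expected step is a 1.5-fold lower number from compound 1 to compound 3 (0.17 log units; within the scatter), probably not beyond the scatter. Compound 3 is estimated at 16 ug/mL in this assay, with a range from 5 ug/mL to 50 ug/mL.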

Compound 3, concentration for 50% growth inhibition: 42.4 ug/mL
Beside the measured number, compound 3's estimate is 2.7-fold (0.42 log units) below it, and the stated range covers the measured number.
By their numbers in this assay, from the lowest: compound 2; then compounds 1 and 3 (each within the scatter of the next).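

In this assay, propyl in place of methylsulfanyl on an aromatic carbon para to a large group gives a 1.8-fold higher number from compound 1 to compound 3 (0.25 log units; within the scatter). At this position, then, the two groups are not told apart, although the methylsulfanyl carries a hydrogen-bond acceptor and the propyl carries none. Nothing available explains this result. Still open, going by these compounds, is whether an amine, a carboxylic acid or a longer chain such as hexyl at this position would move the number beyond the scatter.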